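This account rests on a few compounds, and the source may have more. Where it says the series, first, only, none or still open, it means among the compounds named here.

Compound 1 `Cc1[nH]c2ccccc2c1C1CC(c2ccncc2)=NO1` in a functional assay on PC-3 cells (Homo sapiens) for inhibition, read by MTT assay, with a stated time of 48 h (on this read-out lower numbers stand for stronger inhibition and higher numbers for weaker inhibition), gives 21200 nM.
Compound 2 `Clc1ccc(Cn2cc(C3CC(c4ccncc4)=NO3)c3ccccc32)cc1` in this assay gives 25700 nM.
Compound 3 `COc1ccc2c(C3CC(c4ccncc4)=NO3)c[nH]c2c1` in this assay gives 10500 nM.

Of these three numbers, compound 3 stands lowest, and so strongest; compound 1 sits nearest, beyond the scatter, and compound 2 furthest, also beyond the scatter. Compound 4 `c1ccc2c(C3CC(c4ccncc4)=NO3)c[nH]c2c1` has not yet been measured. It differs from compound 3 in one place: hydrogen in place of methoxy on an aromatic carbon. Among the compounds with values here, no two measured compounds differ in just one place, so no measured step guides this change; compounds 1 and 2 carry other changes on the shared core. In this assay a small step toward a higher number, near the edge of the scatter, is expected. Compound 4 is estimated at 16000 nM, within 6000 nM to 40000 nM. The expected step is a 1.5-fold higher number from compound 3 to compound 4 (0.18 log units; within the scatter).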

Compound 4, half-maximal inhibitory concentration: > 100000 nM
Compound 4 was reported as a limit; the forecaster's own chance of this, stated with the estimate: 10%; middle value at least 6.2-fold (0.79 log units) from the limit.
By their numbers in this assay, from the lowest: compound 3; then compounds 1 and 2 (each within the scatter of the next). At a limit, above all of these: compound 4.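

In this assay compound 4 is reported only as a limit, > 100000 nM. Hydrogen in place of methoxy on this aromatic carbon gives an at least 9.5-fold higher number from compound 3 to compound 4 (0.97 log units; beyond the scatter), so this position is far from indifferent, and the shared core with no added group is the weakest case here: hydrogen in place of 4-chlorobenzyl on the aromatic nitrogen gives an at least 3.8-fold higher number from compound 2 to compound 4 (0.59 log units; beyond the scatter), and hydrogen in place of methyl gives an at least 4.7-fold higher number from compound 1 to compound 4 (0.67 log units; beyond the scatter). Each step is only a minimum, because compound 4 rests at a limit: the limit of > 100000 nM in this assay, at which 1 of the 4 values shown sits.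

The compounds shown leave open whether a different group on this carbon, such as a hydroxyl, an amine or an ethoxy, would match methoxy.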